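The compounds below may be only part of what the source reports. "The series", "measured", "known", "first", "only" and "open" are said of these compounds alone.

Compound 1 `COc1ccc(/C(F)=C(\F)c2cc(OC)c(OC)c(OC)c2)cc1[N+](=O)[O-]` is the weakest of the three measured compounds: in a functional assay on cells (Endothelial cell, Bos taurus) for antiproliferative activity (a lower number here means a stronger inhibitor, a higher number a weaker inhibitor), compound 1 gives 2300000 nM. Compound 2 `COc1ccc(/C(F)=C/c2cc(OC)c(OC)c(OC)c2)cc1N` gives 111000 nM in this assay, and compound 3 `COc1ccc(/C=C\c2cc(OC)c(OC)c(OC)c2)cc1[N+](=O)[O-]` gives 135000 nM; these two numbers lie close together, while compound 1 stands well apart from both. The unmeasured compound 4 `COc1ccc(/C(F)=C(/F)c2cc(OC)c(OC)c(OC)c2)cc1[N+](=O)[O-]` is related to compound 1 as follows: the two compounds have the same atoms and bonds and differ only in configuration as drawn: 1 of 1 stereo elements differ; a double bond is drawn E in compound 1 and Z in compound 4. Within the data shown here, no directly comparable step between measured compounds is available, so the expectation rests on the values shown. Because compound 3 gives 135000 nM while compound 1 gives 2300000 nM, a step toward a lower number is expected, with a 15-fold lower number from compound 1 to compound 4 (1.19 log units; beyond the scatter). Compound 4 is therefore estimated at 150000 nM in this assay, within a range from 20000 nM to 1500000 nM.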

Compound 4, half-maximal inhibitory concentration: 749000 nM
Compound 4: middle estimate off by 5.0-fold (0.70 log units), on the low side; low and high end bracket the measured number.
By their numbers in this assay, from the lowest: compounds 2 and 3 (each within the scatter of the next); then compound 4; then compound 1.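

Among these compounds, there is a 3.1-fold lower number from compound 1 to compound 4 (0.49 log units; beyond the scatter) in this assay when the fluorinated double bond goes from E to Z, the first step here that isolates a single change. Configuration at this double bond therefore matters on its own, with the fluorine atoms and the nitro group unchanged. The shift can be assigned to configuration alone, because nothing else differs: the fact that compounds 1 and 4 differ only in the configuration as drawn.

Going by these compounds, whether a step of this size would persist with a hydroxyl group in place of the nitro group, or with chlorine atoms in place of the fluorine atoms, remains open.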